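This account rests on a few compounds, and the source may have more. Where it says the series, first, only, none or still open, it means among the compounds named here.

Two compounds of this series have results in a physicochemical assay for solubility, using the shake flask method, in simulated intestinal fluid, measured as kinetic solubility, with a stated time of 2 h, at 25 degrees C, at pH 6.5; a higher number here means a more soluble compound, a lower number a less soluble compound. Compound 1 `Cc1nc(C(N)=O)c(N)c2c1C(=O)N(Cc1ccccc1)C2=O` gives < 5000 nM, which is a limit of the assay and not a number. For the measured compounds named here, compound 2 `Cc1noc(-c2nc(C)c3c(c2N)C(=O)N(CC2CCNCC2)C3=O)n1` gives 160000 nM, the only actual number so far. Next comes compound 3 `COc1cccc(CN2C(=O)c3c(C)nc(-c4nc(C)no4)c(N)c3C2=O)c1`, with the change (3-methoxyphenyl in place of piperidin-4-yl on a saturated chain carbon bound to an amide-type nitrogen in a ring). Going by the values given here, no step between measured compounds sizes this change, so the expectation rests on a single comparison. Compound 1 also holds an aromatic ring at that place, and it reads < 5000 nM, again a limit. A large fall in this assay, well beyond the scatter, is therefore expected. The estimated step is a 40-fold lower number from compound 2 to compound 3 (1.60 log units; beyond the scatter). For compound 3 the estimated value is 4000 nM, with an expected range of 1000 nM to 20000 nM.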

Compound 3, solubility: < 5000 nM
Compound 3 was reported as a limit (the forecaster's own chance of this, stated with the estimate: 60%); the middle value lies beyond the limit too.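

In this assay, compound 3 gives < 5000 nM, which is a limit of the assay and not a number. For the compounds shown here, the change from (piperidin-4-yl)methyl to 3-methoxybenzyl on the saturated chain carbon bound to the ring amide-type nitrogen gives an at least 32-fold lower number from compound 2 to compound 3 (1.50 log units; beyond the scatter), the first step that sizes a change at this place, and its true size remains open at the low end. The low end of the series is unresolved: the limit of < 5000 nM in this assay, at which 2 of the 3 values shown sit.

From the compounds shown here alone, how far compound 3 lies past its limit remains open, and so does the full size of the step. The compounds shown also do not separate the departure of the piperidin-4-yl from the entry of the aromatic ring: a cyclohexylmethyl group, or a benzyl carrying a dimethylamino group, on the same core would divide the step.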